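Swapping One Aryl Ring for Another: Liver Clearance

The source may hold more compounds than are shown below. What is called first, only, known or untested is meant among the compounds shown, and "the series" means these compounds.

Measured compounds:
Compound 1 `O=S(=O)(c1cc(F)cc(F)c1)c1cnc2c(F)cccc2c1-c1cccc(Cl)c1` gives 0.64 mL/min
Compound 2 `COc1ccc(-c2c(S(=O)(=O)c3cc(F)cc(F)c3)cnc3c(F)cccc23)cc1` gives 2.59 mL/min
Compound 3 `O=S(=O)(c1ccc(F)c(F)c1)c1cnc2c(F)cccc2c1-c1cccc(Cl)c1` gives 1.13 mL/min

All three were tested in an ADME assay on microsomes from liver (Homo sapiens) for metabolic stability, tested at 2.5 uM; on this read-out lower numbers stand for slow clearance and higher numbers for fast clearance. Compound 1 and compound 2 share a core and differ in one place: 4-methoxyphenyl in place of 3-chlorophenyl on an aromatic carbon. That change gave a 4.0-fold higher number from compound 1 to compound 2 (0.61 log units; beyond the scatter). Compound 3 carries a different core from compound 1; the difference between the two cores is 3,4-difluorophenyl in place of 3,5-difluorophenyl on a sulfonyl sulfur, and it gave a 1.8-fold higher number from compound 1 to compound 3 (0.25 log units; within the scatter).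

Compound 4 `COc1ccc(-c2c(S(=O)(=O)c3ccc(F)c(F)c3)cnc3c(F)cccc23)cc1` has not yet been tested in this assay. It relates to compound 3 exactly as compound 2 relates to compound 1: 4-methoxyphenyl in place of 3-chlorophenyl on an aromatic carbon. The surroundings of the change are the same in both pairs, so this is the same change made on a second core, and the two cores differ only as told by the difference between compound 1 and compound 3.

The expectation for compound 4 rests on one measured step, a 4.0-fold higher number from compound 1 to compound 2 (0.61 log units; beyond the scatter), transferred to the core of compound 3. Compound 4 is therefore expected to show a 3.5-fold higher number from compound 3 to compound 4 (0.55 log units; beyond the scatter), set beside the earlier 4.0-fold higher number from compound 1 to compound 2 (0.61 log units; beyond the scatter). Going by the values given here, with only one prior example of this change, the range is kept wide. Compound 4 is estimated at 4 mL/min, expected to fall between 1.9 mL/min and 8.5 mL/min.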

Compound 4, intrinsic clearance in a liver preparation (reported as CLH), per the amount of preparation that the assay uses: 2.12 mL/min
Estimate against measurement, compound 4: 1.9-fold (0.28 log units) above; the measured number falls inside the stated range.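

In this assay, the aryl swap on the core of compound 3 gave a 1.9-fold higher number from compound 3 to compound 4 (0.27 log units; within the scatter), so this change now has two readings that can be set side by side: the same change on two cores in this assay, a 4.0-fold higher number (0.61 log units; beyond the scatter) from compound 1 to compound 2 and a 1.9-fold higher number (0.27 log units; within the scatter) from compound 3 to compound 4, 2.2-fold (0.33 log units) apart, within the scatter of two such steps. The second change, 3,4-difluorophenyl in place of 3,5-difluorophenyl on the sulfonyl sulfur, now also has a second reading, a 1.2-fold lower number from compound 2 to compound 4 (0.09 log units; within the scatter), and it agrees with the first in the same way: the same change on two cores in this assay, a 1.8-fold higher number (0.25 log units; within the scatter) from compound 1 to compound 3 and a 1.2-fold lower number (0.09 log units; within the scatter) from compound 2 to compound 4, 2.2-fold (0.33 log units) apart, within the scatter of two such steps. The results fit the idea that each change carries from one core to the other, but two pairs on two closely related cores cannot prove that a change has the same size on both, and they cannot separate a small real difference from ordinary scatter.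

As far as these compounds go, the aryl group on the shared core appears here only as 3-chlorophenyl or 4-methoxyphenyl, so it remains open how the clearance read-out would respond to a phenyl ring carrying an amine or a carboxylic acid. Also open, from the compounds shown here alone, is whether the 4-methoxyphenyl change would carry over as well to a core that differs by more than its difluorophenyl group.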